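The compounds below may be only part of what the source reports. "The series", "measured", "known", "first", "only" and "open" are said of these compounds alone.

Four compounds share the same pattern: an oxygen on an aromatic ring carries a saturated chain that ends in a hydroxycarbamoyl group, and all were examined in a functional assay on PC-3 cells (Homo sapiens) for antiproliferative activity, read by sulforhodamine B assay, with a stated time of 48 h; a higher number here means a weaker inhibitor of growth, a lower number a stronger inhibitor of growth. Compound 1 `CC(C)CCc1c(OCCCCCC(=O)NO)ccc2ccc(=O)oc12` gives 740 nM. Compound 2 `CC(C)CCc1c(OCCCCC(=O)NO)ccc2ccc(=O)oc12` differs from it by hydroxycarbamoyl in place of (hydroxycarbamoyl)methyl on a saturated chain carbon, four bonds along the chain from an oxygen on an aromatic ring; compound 2 gives 1940 nM, and the step of a 2.6-fold higher number from compound 1 to compound 2 (0.42 log units; beyond the scatter). Compound 3 `CC(C)CCc1c(OCCCCCC(=O)NO)ccc2c1OC(=O)CC2` is built on a different core; how the two cores differ is not broken down here. For compound 3 only a limit of the assay is reported, > 30000 nM. Compound 4 `CC(C)CCc1c(OCCCCC(=O)NO)ccc2c1OC(=O)CC2` stands to compound 3 as compound 2 stands to compound 1, the same kind of change: hydroxycarbamoyl in place of (hydroxycarbamoyl)methyl on a saturated chain carbon, four bonds along the chain from an oxygen on an aromatic ring. Two things shape the expectation for compound 4: the shorter chain weakened growth inhibition in a 2.6-fold higher number from compound 1 to compound 2 (0.42 log units; beyond the scatter), and compound 3 already sits at the limit of > 30000 nM in this assay, at which 1 of the 3 values shown sits. The step that the limit leaves unreadable from compound 3 to compound 4 is therefore expected to point the same way, though it can hardly be resolved from a limit. Compound 4 is estimated at 60000 nM, between 20000 nM and 200000 nM, most probably reported again only as a limit.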

Compound 4, concentration for 50% growth inhibition: > 30000 nM
Compound 4: a limit, no number; the forecaster's own chance of this, stated with the estimate: 85%; the middle value is on the limit's open side.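

In this assay, among these compounds, compound 3 and compound 4 are both reported only as a limit, not a number, so no step between them can be read: the limit of > 30000 nM in this assay, at which 2 of the 4 values shown sit. The compounds shown leave open whether swapping (hydroxycarbamoyl)methyl for hydroxycarbamoyl changes growth inhibition at all on the core of compound 3, as it does on the core of compound 1.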